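The source may hold more compounds than are shown below. What is called first, only, known or untested is meant among the compounds shown, and "the series" means these compounds.

In a functional assay on A549 cells (Homo sapiens) for cytotoxicity, read by MTT assay, with a stated time of 72 h (on this read-out higher numbers stand for weaker inhibition and lower numbers for stronger inhibition), compound 1 `O=C(c1ccccc1)c1sc(N2CCCC2)nc1Cl` gives 50000 nM and compound 2 `O=C(c1ccccc1)c1sc(N2CCCC2)nc1Br` gives 97000 nM. For the measured compounds named here, the only measured step between them is a 1.9-fold higher number from compound 1 to compound 2 (0.29 log units; within the scatter), so the two stand level. Compound 3 `N#Cc1sc(N2CCCC2)nc1Cl` returns only a limit, > 100000 nM.

Compound 4 `O=C(c1ccccc1)c1sc(N2CCCCC2)nc1Br` has piperidin-1-yl in place of pyrrolidin-1-yl on an aromatic carbon of the shared core: piperidin-1-yl in place of pyrrolidin-1-yl on an aromatic carbon. Going by the values given here, no measured step covers this place. The bromo for chloro swap, a 1.9-fold higher number from compound 1 to compound 2 (0.29 log units; within the scatter), sits elsewhere and offers only a loose guide, so no step beyond the scatter is expected in this assay. The estimated step is a 1.2-fold lower number from compound 2 to compound 4 (0.08 log units; within the scatter). Compound 4 may also end at the limit of > 100000 nM in this assay, at which 1 of the 3 values shown sits. Compound 4 is expected at 80000 nM, with an estimated range of 40000 nM to 160000 nM.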

Compound 4, half-maximal inhibitory concentration: 48000 nM
Beside the measured number, compound 4's estimate is 1.7-fold (0.22 log units) above it; the measured number falls inside the stated range.
By their numbers in this assay, from the lowest: compounds 4, 1 and 2 (each within the scatter of the next, the first and the last beyond it). At a limit, above all of these: compound 3.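

The position next to the ring nitrogen and next to the ring sulfur now has a measured step: in this assay, six-membered piperidin-1-yl in place of five-membered pyrrolidin-1-yl gives a 2.0-fold lower number from compound 2 to compound 4 (0.31 log units; beyond the scatter). For the compounds shown here, this modest step is the first beyond the scatter, while the bromo for chloro swap gave a 1.9-fold higher number from compound 1 to compound 2 (0.29 log units; within the scatter). Compound 3 remains a limit and gives no step: the limit of > 100000 nM in this assay, at which 1 of the 4 values shown sits.

On these data alone, whether the piperidin-1-yl step carries over to the chloro series of compound 1 stays open. So does the effect of morpholin-4-yl or an open-chain dimethylamino group at this position.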